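Naphthalen-2-yl Replaces Ethynyl on the Nucleotide Side Chain

The compounds below may be only part of what the source reports. "The series", "measured", "known", "first", "only" and "open" are said of these compounds alone.

Going by the values given here, compound 2 `C#CCCCO/N=c1/ccn([C@@H]2O[C@H](COP(=O)(O)OP(=O)(O)OP(=O)(O)O)[C@@H](O)[C@H]2O)c(=O)[nH]1` gives 410 nM in a functional assay on 1321-N1 cells for agonist activity at P2Y purinoceptor 4 (Homo sapiens), read by scintillation counting and inositol phosphate accumulation (a higher number here means that more compound is needed for the effect, a lower number that less compound is needed), the highest of the two numbers measured so far, while compound 1 `O=c1[nH]/c(=N\OCCCc2ccc([N+](=O)[O-])cc2)ccn1[C@@H]1O[C@H](COP(=O)(O)OP(=O)(O)OP(=O)(O)O)[C@@H](O)[C@H]1O` gives 84 nM. Compound 3 `O=c1[nH]/c(=N\OCCCc2ccc3ccccc3c2)ccn1[C@@H]1O[C@H](COP(=O)(O)OP(=O)(O)OP(=O)(O)O)[C@@H](O)[C@H]1O` differs from compound 2 by naphthalen-2-yl in place of ethynyl on a saturated chain carbon, three bonds along the chain from an oxygen on an unsaturated carbon. Among the compounds with values here, the one measured step that bears on this change is a 4.9-fold higher number from compound 1 to compound 2 (0.69 log units; beyond the scatter), in which a group with an aromatic ring on a saturated chain carbon gave the lower number. A step of similar size in the opposite direction is therefore expected, a 4.1-fold lower number from compound 2 to compound 3 (0.61 log units; beyond the scatter). Compound 3 is estimated at 100 nM, with a range from 35 nM to 300 nM.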

Compound 3, half-maximal effective concentration: 128 nM
Compound 3: middle estimate off by 1.3-fold (0.11 log units), on the low side; the measured number falls inside the stated range.
By their numbers in this assay, from the lowest: compounds 1 and 3 (each within the scatter of the next); then compound 2.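

Putting naphthalen-2-yl in place of ethynyl gives a 3.2-fold lower number from compound 2 to compound 3 (0.51 log units; beyond the scatter) in this assay, so the lower number seen with 4-nitrophenyl is not confined to that one aromatic group. The two aromatic groups cannot be told apart here, with a 1.5-fold higher number from compound 1 to compound 3 (0.18 log units; within the scatter). No evidence is at hand to explain either step.

The compounds shown leave open whether an aromatic ring is needed at this place, or whether a saturated ring such as cyclohexyl would serve as well. They also leave open how an amine, a carboxylic acid or a longer chain would read here.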